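Sulfanyl substituents on the triazole carbon of a bicyclic series

The source may hold more compounds than are shown below. What is called first, only, known or untested is meant among the compounds shown, and "the series" means these compounds.

Compound 1 `Cc1cc(N2CC[C@@H](C)[C@@H](N(C)c3ncnc4[nH]ccc34)C2)n2ncnc2n1` is the parent of this small set. In a functional assay on HGC-27 cells (Homo sapiens) for inhibition, read by MTT assay, with a stated time of 72 h (on this read-out higher numbers stand for weaker inhibition and lower numbers for stronger inhibition), compound 1 gives 11300 nM, the lowest of the two numbers in hand, with compound 2 the nearest to it. Compound 2 `Cc1cc(N2CC[C@@H](C)[C@@H](N(C)c3ncnc4[nH]ccc34)C2)n2nc(SCC3CCCCC3)nc2n1` carries (cyclohexylmethyl)sulfanyl in place of hydrogen on an aromatic carbon and in this assay gives 11500 nM; the step of a 1.0-fold higher number from compound 1 to compound 2 (0.01 log units; within the scatter) shows that this addition left the number unchanged within the scatter.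

Compound 3 `Cc1cc(N2CC[C@@H](C)[C@@H](N(C)c3ncnc4[nH]ccc34)C2)n2nc(SCc3cc(Cl)ccc3Cl)nc2n1` is the next member, differing from compound 1 by (2,5-dichlorobenzyl)sulfanyl in place of hydrogen on an aromatic carbon. The group enters on an aromatic carbon of a five-membered aromatic ring with 3 nitrogen, part of a fused system of two rings, between two ring nitrogen atoms, the same place that takes the substituent in compound 2. Within the data shown here, only the step from compound 1 to compound 2 bears on this change, and it was within the scatter. A number close to that of compound 1 is therefore expected for compound 3, with no step beyond the scatter in either direction; the expected step is a 1.0-fold lower number from compound 1 to compound 3 (0.01 log units; within the scatter). Compound 3 is estimated at 11000 nM, within a range of 5000 nM to 25000 nM.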

Compound 3, half-maximal inhibitory concentration: 19200 nM
Beside the measured number, compound 3's estimate is 1.7-fold (0.24 log units) below it; the measured number falls inside the stated range.
By their numbers in this assay, from the lowest: compounds 1, 2 and 3 (each within the scatter of the next).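

In this assay the aromatic carbon between two ring nitrogen atoms takes (2,5-dichlorobenzyl)sulfanyl with a 1.7-fold higher number from compound 1 to compound 3 (0.23 log units; within the scatter) and so stays within the scatter of the parent, which extends the reading from one sulfanyl substituent to a second that ends in a six-membered aromatic ring of carbon only. The exchange of cyclohexyl for 2,5-dichlorophenyl on the saturated chain carbon bound to a sulfur, with a 1.7-fold higher number from compound 2 to compound 3 (0.22 log units; within the scatter) as its result, adds a direct comparison of the two ring ends, and on this read-out that comparison does not separate them. Nothing available bears on why the three compounds stay within the scatter of one another.

On these data alone, whether an amine or a carboxylic acid on this aromatic carbon, or an ether oxygen in place of the sulfur, would give a step beyond the scatter remains open. Also open, as far as these compounds go, is whether a longer chain between the sulfur and the ring, or a benzyl ring with a single chlorine, would read any differently from compound 3 in this assay on the same core.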